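Changing the Aryl Group on a Sulfonyl Sulfur

The source may hold more compounds than are shown below. What is called first, only, known or untested is meant among the compounds shown, and "the series" means these compounds.

Measured in a functional assay on K562 cells (Homo sapiens) for inhibition, read by trypan blue exclusion, with a stated time of 72 h; a higher number here means a weaker inhibitor, a lower number a stronger inhibitor:
compound 1 `Cn1c(=O)c(C(=O)Nc2ccc(F)cc2F)cc2cnc(Nc3ccc4[nH]ccc4c3)nc21` gives 5000 nM
compound 2 `COc1ccc(S(=O)(=O)c2cc3cnc(Nc4ccc5[nH]ccc5c4)nc3n(C)c2=O)cc1` gives 300 nM
compound 3 `COc1ccc(S(=O)(=O)c2cc3cnc(Nc4cccc5[nH]ccc45)nc3n(C)c2=O)cc1` gives 5000 nM

Compound 2 has the lowest number of the three, and its steps to the other two both lie beyond the scatter. Compound 4 `Cn1c(=O)c(S(=O)(=O)c2ccc(F)cc2[N+](=O)[O-])cc2cnc(Nc3ccc4[nH]ccc4c3)nc21` differs from it in one place: 4-fluoro-2-nitrophenyl in place of 4-methoxyphenyl on a sulfonyl sulfur. In words, this is 4-fluoro-2-nitrophenyl in place of 4-methoxyphenyl on a sulfonyl sulfur.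

Going by the values given here, no measured pair compares two groups on the sulfonyl sulfur, so the evidence is indirect. The closest is a 17-fold lower number from compound 1 to compound 2 (1.22 log units; beyond the scatter), a large change that brought in the (4-methoxyphenyl)sulfonyl group. The other, a 17-fold higher number from compound 2 to compound 3 (1.22 log units; beyond the scatter), is equally large, but it concerns the indole attachment, which compound 4 leaves unchanged. Among the compounds with values here, it shows only that single changes can matter greatly.

Compound 2 already stands lowest at 300 nM, so a moderate move towards a higher number seems most likely. The expected change is a 2.7-fold higher number from compound 2 to compound 4 (0.43 log units; beyond the scatter). Compound 4 is estimated at 800 nM, with an expected range of 200 nM to 3500 nM.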

Compound 4, half-maximal inhibitory concentration: 900 nM
Estimate against measurement, compound 4: 1.1-fold (0.05 log units) below; the range from low to high includes it.
By their numbers in this assay, from the lowest: compound 2; then compound 4; then compounds 1 and 3 (each within the scatter of the next).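

Going by these compounds alone, this is the first direct comparison of two aryl groups on the sulfonyl sulfur. In this assay, the change to 4-fluoro-2-nitrophenyl gives (a 3.0-fold higher number from compound 2 to compound 4 (0.48 log units; beyond the scatter)), so the aryl group here does affect the number, though this modest step is smaller than the large one that brought in the sulfonyl group (a 17-fold lower number from compound 1 to compound 2 (1.22 log units; beyond the scatter)). No measurement shown here explains the rise in the number.

The new ring carries two groups that the 4-methoxyphenyl ring lacks, a fluorine and a nitro group, and it also loses the methoxy group, so the step cannot be divided among these changes. Still open, from the compounds shown here alone, is how an unsubstituted phenyl, a 4-fluorophenyl or a methyl group on the sulfonyl sulfur would compare with 4-methoxyphenyl.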